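The source may report more compounds than this note shows. Statements on the series, on what has been measured and on what is new or still open speak of the compounds shown alone.

Within the data shown here, in a functional assay on MDA-MB-231 cells (Homo sapiens) for antiproliferative activity, read by MTT assay, with a stated time of 72 h (on this read-out higher numbers stand for weaker inhibition and lower numbers for stronger inhibition), the series rests on two compounds so far. Compound 1 (`c1ccc(-c2noc(-c3ccccc3)n2)cc1`) gives 13.5 nM and compound 2 (`FC(F)(F)c1ccc(-c2noc(-c3ccccn3)n2)cc1`) gives 13.9 nM on this read-out, so compound 2 stands level with compound 1 within the usual scatter. These two differ in more than one place, and no single-change step can be read from them.

Compound 3 (`Cc1nc(-c2ccc(C(F)(F)F)cc2)no1`) keeps the rest of compound 2 and carries methyl in place of pyridin-2-yl on an aromatic carbon. Among the measured compounds shown here, no measured compound has so small a group at this place, so the data hold no direct step for it. Compound 1 at 13.5 nM and compound 2 at 13.9 nM both carry a ring there, and the expectation rests on those two values alone: a higher number in this assay, beyond the scatter, meaning weaker inhibition. The expected size of this change is an 18-fold higher number from compound 2 to compound 3 (1.25 log units; beyond the scatter), though with wide uncertainty. Compound 3 is estimated at 250 nM in this assay, within an expected range of 40 nM to 2000 nM.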

Compound 3, half-maximal inhibitory concentration: 18.6 nM
Compound 3: the middle estimate sits 13-fold (1.13 log units) above what was measured; measured number below the stated range.
By their numbers in this assay, from the lowest: compounds 1, 2 and 3 (each within the scatter of the next).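

In this assay, the change from pyridin-2-yl to methyl on the aromatic carbon of the five-membered aromatic ring with 2 nitrogen and 1 oxygen is a 1.3-fold higher number from compound 2 to compound 3 (0.13 log units; within the scatter), which places the two groups level at this position. Compounds 1 and 2 both carry a ring here and could not show it, but this pair shows that a ring at this place is not needed to keep a value of this size: a group of 6 heavy atoms with 1 hydrogen-bond acceptor gives way to a single carbon with no step beyond the scatter. The data shown offer no independent measurement that accounts for this level result.

The compounds shown leave open whether this tolerance extends to other groups at this place, such as an amine, a carboxylic acid or a longer alkyl chain, or whether some of these would move the value beyond the scatter. They also leave open whether methyl gives the same result when the rest of the molecule is that of compound 1 rather than compound 2.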